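A few compounds are considered here, and "the series" means these few. Any claim that something is new, unique, unknown or untested is made for them only; others in the source may bear on it.

Compound 1 `COc1cccc(F)c1-c1cccc2nc(Nc3ccccc3)oc12` carries a plain phenyl group on the amine attached to the shared core. In an assay on BAF cells for inhibition of ribosomal protein S6 kinase alpha-2 (Mus musculus) (a higher number here means a weaker inhibitor, a lower number a stronger inhibitor), compound 1 gives only a limit of the assay, > 20000 nM. Compound 2 `COc1cc(Nc2nc3cccc(-c4c(F)cccc4OC)c3o2)cc(OC)c1OC` carries further methoxy groups on that ring, and in this assay compound 2 gives 2600 nM. Compound 3 `COc1ccc(Nc2nc3cccc(-c4c(F)cccc4OC)c3o2)cc1` differs from compound 1 by methoxy in place of hydrogen on an aromatic carbon, a methoxy in place of hydrogen on an aromatic carbon. A modest gain is expected for the step of an at least 2.0-fold lower number from compound 1 to compound 3 (0.30 log units; that floor lies within the scatter) in this assay. Compound 3 is estimated at 10000 nM, with a range from 3000 nM to 40000 nM.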

Compound 3, half-maximal inhibitory concentration: > 20000 nM
Compound 3 was reported as a limit; the forecaster's own chance of this, stated with the estimate: 45%; at least 2.0-fold (0.30 log units) between middle value and limit.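

No step can be read from compound 1 to compound 3, as both values are limits: the limit of > 20000 nM in this assay, at which 2 of the 3 values shown sit. Within the data shown here, whether the single methoxy of compound 3 changes the inhibition in this assay at all, and by how much, stays open.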